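A few compounds are considered here, and "the series" means these few. Any claim that something is new, unique, unknown or untested is made for them only; others in the source may bear on it.

Of the compounds shown here, three have been measured in a functional assay on DU-145 cells (Homo sapiens) for inhibition, read by trypan blue exclusion, with a stated time of 96 h; on this read-out lower numbers stand for stronger inhibition of growth and higher numbers for weaker inhibition of growth. Compound 1, `Cc1ccc(CS/C(=C/c2ccc(Cl)c([N+](=O)[O-])c2)C(=O)c2ccc(C(=O)O)cc2)cc1`, gives 1000 nM. Compound 2, `CN(C)c1ccc(/C=C(/SCc2ccc(Cl)cc2Cl)C(=O)c2ccc(Cl)cc2)cc1`, gives 50000 nM. Compound 3, `Cc1ccc(CS/C(=C/c2ccc(N(C)C)cc2)C(=O)c2ccc(Cl)cc2)cc1`, gives only a limit of the assay, > 100000 nM.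

Compound 1 stands lowest of the two numbers, and compound 2 sits far above it. Compound 3 and compound 2 differ in one place, (2,4-dichlorophenyl in place of 4-methylphenyl on a saturated chain carbon bound to a sulfur), and that change gave an at least 2.0-fold lower number from compound 3 to compound 2 (0.30 log units; that floor lies within the scatter); the step is only a floor because of the limit of > 100000 nM in this assay, at which 1 of the 3 values shown sits. The difference between the core of compound 1 and the core of compound 3 is not broken down here. Compound 4, `O=C(O)c1ccc(C(=O)/C(=C\c2ccc(Cl)c([N+](=O)[O-])c2)SCc2ccc(Cl)cc2Cl)cc1`, carries the same change made on compound 1: 2,4-dichlorophenyl in place of 4-methylphenyl on a saturated chain carbon bound to a sulfur. In this assay the expected step is a 1.7-fold lower number from compound 1 to compound 4 (0.22 log units; within the scatter), a modest lowering that rests on an at least 2.0-fold lower number from compound 3 to compound 2 (0.30 log units; that floor lies within the scatter). Compound 4 is therefore estimated at 600 nM, with a likely range from 200 nM to 2500 nM.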

Compound 4, concentration for 50% growth inhibition: 1000 nM
Compound 4: middle estimate off by 1.7-fold (0.22 log units), on the low side; measured number inside the range.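

In this assay, 2,4-dichlorophenyl in place of 4-methylphenyl on the core of compound 1 gives no change at the digits printed from compound 1 to compound 4 (within the scatter), so on this core the swap leaves the number within the usual scatter. Set beside the same swap on the core of compound 3, this shows neither that the change carries over from one core to the other nor that it fails to, since one step is only a floor: the same change on two cores in this assay, an at least 2.0-fold lower number (0.30 log units; that floor lies within the scatter) from compound 3 to compound 2 and no change at the digits printed (within the scatter) from compound 1 to compound 4; the limit leaves it open whether they differ. Compound 3 sits at a limit of the assay: the limit of > 100000 nM in this assay, at which 1 of the 4 values shown sits.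

On these data alone, what a pyridine ring or a longer chain would do at this same place stays open. So does how the change behaves on a third core.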